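A Second Chloro on the Core of Compound 1

The compounds below may be only part of what the source reports. "The series", "measured", "known", "first", "only" and "open" are said of these compounds alone.

Compound 1 `ClCc1ccccc1Cn1cnc2ncnc(Cl)c21` holds the lower of the two numbers at hand. In a functional assay on HOP-92 cells (Homo sapiens) for cytotoxicity, read by sulforhodamine B assay, with a stated time of 48 h (a higher number here means a weaker inhibitor of growth, a lower number a stronger inhibitor of growth), compound 1 gives 12900 nM. Its nearest neighbour, compound 2 `Nc1nc(Cl)c2ncn(Cc3cccc(CCl)c3)c2n1`, gives 38000 nM in this assay, a number beyond the scatter from that of compound 1. Compound 3 `ClCc1ccccc1Cn1cnc2nc(Cl)nc(Cl)c21` differs from compound 1 by chloro in place of hydrogen on an aromatic carbon. For the measured compounds named here, no measured pair shows such a change here, so the size of the step is open; compound 3 is expected to sit close to compound 1, with no step beyond the scatter in either direction. Compound 3 is estimated at 10000 nM, within 4000 nM to 30000 nM. The expected step is a 1.3-fold lower number from compound 1 to compound 3 (0.11 log units; within the scatter).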

Compound 3, concentration for total growth inhibition: 2810 nM
The estimate for compound 3 lay 3.6-fold (0.55 log units) above the measured number, outside the stated range (below it).
By their numbers in this assay, from the lowest: compound 3; then compound 1; then compound 2.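

Chloro in place of hydrogen on this aromatic carbon, between two ring nitrogen atoms, gives a 4.6-fold lower number from compound 1 to compound 3 (0.66 log units; beyond the scatter) in this assay, the first step in the series that can be read. The position is therefore not silent: one added chlorine, meta to the chloro group already on the core, moves the number toward stronger inhibition of growth. No evidence at hand bears on why this happens. Going by these compounds, whether fluoro, methyl or methoxy at this position would give a step of similar size remains open. So does whether the step holds on another core.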